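A few compounds are considered here, and "the series" means these few. Any claim that something is new, unique, unknown or untested is made for them only; others in the source may bear on it.

Measured so far:

- Compound 1, `COC(=O)CC(=O)Nc1cccc2c(=O)cc(C(=O)O)oc12`: 6650 nM in an assay on CHO cells for agonist activity at G protein-coupled receptor GPR35 (Rattus norvegicus), read by a beta-galactosidase reporter and beta-arrestin recruitment, with a stated time of 90 min; a lower number here means that less compound is needed, a higher number that more compound is needed for the effect
- Compound 2, `COc1ccc(C(=O)Nc2cc(Br)cc3c(=O)cc(C(=O)O)oc23)c(Cl)c1`: 4170 nM in this assay

Both compounds share a core carrying a carboxylic acid and an amide nitrogen, and they differ in what sits on the amide carbonyl carbon. Compound 2 has the lowest of the two numbers in this assay, but compound 1 lies close to it: the gap between the two falls within the usual scatter of repeated measurements, so the two cannot be ranked against each other.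

The next compound, compound 3 with the structure `COc1ccccc1C(=O)Nc1cc(Br)cc2c(=O)cc(C(=O)O)oc12`, keeps the core and the bromine of compound 2. Going by the values given here, its only change is 2-methoxyphenyl in place of 2-chloro-4-methoxyphenyl on a carbonyl carbon. Among the compounds with values here, because no pair of measured compounds differs in a single place, no measured step exists to anchor this change; the only guide is that the two measured compounds, with very different groups on the carbonyl carbon, sit at about the same level in this assay. The step from compound 2 to compound 3 is therefore expected to be small, most likely none beyond the scatter, with a modest chance of a weaker result. Compound 3 is expected to give an estimated 6000 nM in this assay, within a range from 2000 nM to 18000 nM, which corresponds to an expected step of a 1.4-fold higher number from compound 2 to compound 3 (0.16 log units; within the scatter).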

Compound 3, half-maximal effective concentration: 1100 nM
The estimate for compound 3 lay 5.5-fold (0.74 log units) above the measured number, outside the stated range (below it).
By their numbers in this assay, from the lowest: compound 3; then compounds 2 and 1 (each within the scatter of the next).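

Going by these compounds alone, the earlier compounds differed in more than one place, so this is the first pair to isolate the group on a carbonyl carbon whose other neighbour is the amide-type nitrogen. In this assay, 2-methoxyphenyl in place of 2-chloro-4-methoxyphenyl gives a 3.8-fold lower number from compound 2 to compound 3 (0.58 log units; beyond the scatter), a real change beyond the scatter, so the substituents on this aromatic ring do affect the number, and the version without chlorine needs less compound for the effect. No measurement here explains why this step occurs.

This single swap removes the chlorine and also changes where the methoxy group sits, as the numbers in the two group names show, so the compounds shown cannot say which of these differences accounts for the step or whether both contribute. They also leave open how the number would respond to a 2-chlorophenyl group, an unsubstituted phenyl group or a 2-ethoxyphenyl group on the same carbonyl carbon, and those comparisons would begin to separate the roles of the chlorine and the methoxy group.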